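A Second Chloro Group on the Shared Core, Twice

The source may hold more compounds than are shown below. What is called first, only, known or untested is meant among the compounds shown, and "the series" means these compounds.

Compound 2 `ClCc1ccccc1Cn1cnc2c(Cl)ncnc21` and compound 3 `ClCc1cccc(Cn2cnc3c(Cl)ncnc32)c1` are built from the same atoms joined differently; the difference between their two cores is not broken down here. In a functional assay on MDA-MB-231 cells (Homo sapiens) for cytotoxicity, read by sulforhodamine B assay, with a stated time of 48 h (a lower number here means a stronger inhibitor of growth, a higher number a weaker inhibitor of growth), compound 2 gives 3020 nM, and in this assay compound 3 gives 1990 nM, two values that lie within the usual scatter of each other. Among the compounds with values here, compound 1 `ClCc1ccccc1Cn1cnc2c(Cl)nc(Cl)nc21` differs from compound 2 by a single change, (chloro in place of hydrogen on an aromatic carbon), and in this assay compound 1 gives 330 nM, the one step in this set that reaches beyond the scatter: a 9.2-fold lower number from compound 2 to compound 1 (0.96 log units; beyond the scatter).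

Compound 4 `ClCc1cccc(Cn2cnc3c(Cl)nc(Cl)nc32)c1` has not yet been measured. It stands to compound 3 exactly as compound 1 stands to compound 2, (chloro in place of hydrogen on an aromatic carbon), the place of the change being described in the same words in both cases, so it is the same change on a core that is itself joined differently.

Within the data shown here, a step of about the same size is expected for compound 4 in this assay, because the earlier step was a 9.2-fold lower number from compound 2 to compound 1 (0.96 log units; beyond the scatter), with only one such step to rest on; the expected step is an 8.0-fold lower number from compound 3 to compound 4 (0.90 log units; beyond the scatter). Compound 4 is therefore estimated at 250 nM, expected to fall between 100 nM and 700 nM.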

Compound 4, concentration for 50% growth inhibition: 1950 nM
For compound 4 the middle estimate is 7.8-fold (0.89 log units) below the measured one; the whole stated range lies below it.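

In this assay, chloro in place of hydrogen on an aromatic carbon, between two ring nitrogen atoms, gives a 1.0-fold lower number from compound 3 to compound 4 (0.01 log units; within the scatter), so the large step seen on the core of compound 2 did not carry over to the differently joined core of compound 3. The two steps do not agree, and the same change cannot be assumed to give the same result on both cores in this series: the same change on two cores in this assay, a 9.2-fold lower number (0.96 log units; beyond the scatter) from compound 2 to compound 1 and a 1.0-fold lower number (0.01 log units; within the scatter) from compound 3 to compound 4, 9.0-fold (0.95 log units) apart, beyond the scatter of two such steps

This does not show which feature of the two cores separates the results, and with a single pair on each core it gives no rule for how the change would behave on any further core.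

The compounds shown carry only hydrogen or chloro between the two ring nitrogen atoms, so it remains open how an amine or a methoxy group at that place would read on either core. On these data alone, it also remains open whether the contrast between the two cores would hold in cells other than those of this assay.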